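From 4-chlorophenyl to 3-methoxyphenyl on a shared core

A few compounds are considered here, and "the series" means these few. Any claim that something is new, unique, unknown or untested is made for them only; others in the source may bear on it.

Values so far in a functional assay on PANC-1 cells (Homo sapiens) for inhibition, read by MTT assay, with a stated time of 24 h; on this read-out lower numbers stand for stronger inhibition and higher numbers for weaker inhibition
Compound 1 `CC1(C)[C@H]2CC[C@]1(C)N(Cc1cn(-c3cccc(Br)c3)nn1)C(=O)C2` gives 90 nM in this series
Compound 2 `CC1(C)[C@H]2CC[C@]1(C)N(Cc1cn(-c3ccc(Cl)cc3)nn1)C(=O)C2` gives 440 nM in this series

Compound 2 stands at the higher of these two numbers, which makes it the weaker of the pair. Still unmeasured is compound 3 `COc1cccc(-n2cc(CN3C(=O)C[C@@H]4CC[C@@]3(C)C4(C)C)nn2)c1` which has the same core. Its difference from compound 2 is 3-methoxyphenyl in place of 4-chlorophenyl on an aromatic nitrogen and amounts to 3-methoxyphenyl in place of 4-chlorophenyl on an aromatic nitrogen.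

Going by the values given here, one measured step bears on this change. It is a 4.9-fold higher number from compound 1 to compound 2 (0.69 log units; beyond the scatter) and it is modest, with 4-chlorophenyl in place of 3-bromophenyl on an aromatic nitrogen. Among the compounds with values here, the name 3-methoxyphenyl carries the same number as the 3-bromophenyl of compound 1 at 90 nM so a partial move back toward that value is expected in this assay and no larger a step than the measured one. Within the data shown here, no measured compound carries a methoxy group, so this expectation remains loose.

The estimated change is a 2.2-fold lower number from compound 2 to compound 3 (0.34 log units; beyond the scatter) towards a lower number. For compound 3 the expected value is 200 nM with an estimated range from 70 nM to 550 nM as its span.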

Compound 3, half-maximal inhibitory concentration: 860 nM
Compound 3: middle estimate off by 4.3-fold (0.63 log units), on the low side; measured number above the stated range.
By their numbers in this assay, from the lowest: compound 1; then compounds 2 and 3 (each within the scatter of the next).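

In this assay the step of a 2.0-fold higher number from compound 2 to compound 3 (0.29 log units; within the scatter) stays within the usual scatter, so 3-methoxyphenyl and 4-chlorophenyl on this aromatic nitrogen cannot be told apart on this read-out, even though the two groups differ in their substituent and in where it sits on the phenyl ring. The shared number in the names of 3-methoxyphenyl and 3-bromophenyl did not bring the two compounds together: methoxy in place of bromo on an aromatic carbon gives a 9.6-fold higher number from compound 1 to compound 3 (0.98 log units; beyond the scatter) and lies beyond the scatter, which leaves compound 1 as the only one of the three set apart from the others. Nothing available accounts for this separation between the bromo and methoxy compounds.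

The compounds shown leave open whether the low value of compound 1 goes with bromo itself or with the place it occupies, as compound 1 and compound 2 differ in both the halogen and its place on the phenyl ring. A 4-bromophenyl and a 3-chlorophenyl on the same nitrogen would separate these two readings, and a 3-methylphenyl would show whether a carbon substituent at that place behaves like bromo or like methoxy.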